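Methoxy in Place of Trifluoromethyl: What to Expect

This account rests on a few compounds, and the source may have more. Where it says the series, first, only, none or still open, it means among the compounds named here.

Of the compounds shown here, two built on one shared core have been tested in a functional assay on HL-60 cells (Homo sapiens) for antiproliferative activity, with a stated time of 24 h; a higher number here means a weaker inhibitor, a lower number a stronger inhibitor. Compound 1 `N#Cc1ccccc1CN1CCc2c(sc(NC(=O)c3ccccc3Cl)c2C(N)=O)C1` gives 10400 nM. Compound 2 `NC(=O)c1c(NC(=O)c2ccccc2Cl)sc2c1CCN(C(=S)Nc1ccc(C(F)(F)F)cc1)C2` gives 7590 nM, the lower of the two numbers, though its gap to compound 1 lies within the scatter. Compound 3 `COc1ccc(NC(=S)N2CCc3c(sc(NC(=O)c4ccccc4Cl)c3C(N)=O)C2)cc1` differs from compound 2 only in that (methoxy in place of trifluoromethyl on an aromatic carbon). Among the compounds with values here, no measured pair shows this particular change, so in this assay the expected step is a 1.2-fold higher number from compound 2 to compound 3 (0.07 log units; within the scatter), within the scatter and with no clear direction. Compound 3 is therefore estimated at 9000 nM, with a range from 3000 nM to 30000 nM.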

Compound 3, half-maximal inhibitory concentration: 15700 nM
Compound 3: the middle estimate sits 1.7-fold (0.24 log units) below what was measured; low and high end bracket the measured number.
By their numbers in this assay, from the lowest: compounds 2, 1 and 3 (each within the scatter of the next, the first and the last beyond it).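

Within the data shown here, putting methoxy in place of trifluoromethyl on the aromatic carbon para to a large group gives a 2.1-fold higher number from compound 2 to compound 3 (0.32 log units; beyond the scatter) in this assay and is the first step here beyond the scatter, so the group at this position has a modest bearing on the number. The larger exchange on the ring amine nitrogen gives a 1.5-fold higher number from compound 1 to compound 3 (0.18 log units; within the scatter) and separates nothing. No available evidence explains the methoxy step.

A single pair sets no trend for this position. As far as these compounds go, how an amine, a carboxylic acid or a longer chain would fare there stays open.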